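Swapping Cyclohexylmethyl for Pyridinylmethoxy on an Amide Carbonyl

This account rests on a few compounds, and the source may have more. Where it says the series, first, only, none or still open, it means among the compounds named here.

Measured so far in an assay on CHO-K1 cells for displacement of a labelled ligand from prostaglandin E2 receptor EP1 subtype (Homo sapiens); on this read-out lower numbers stand for stronger inhibition and higher numbers for weaker inhibition:
Compound 1 `Cc1cc(C(=O)NCc2ccncc2)nn1Cc1cc(Cl)ccc1OCc1ccccc1` gives 79.4 nM.
Compound 2 `CC(=O)Nc1cc(C)n(Cc2cc(Cl)ccc2OCc2ccccc2)n1` gives 316 nM.
Compound 3 `Cc1cc(NC(=O)CC2CCCCC2)nn1Cc1cc(Cl)ccc1OCc1ccccc1` gives 6.31 nM.

Compound 3 stands lowest of the three numbers, and both gaps to it lie beyond the usual scatter: a 13-fold lower number from compound 1 to compound 3 (1.10 log units; beyond the scatter) and a 50-fold lower number from compound 2 to compound 3 (1.70 log units; beyond the scatter). Compound 4 `Cc1cc(NC(=O)OCc2ccccn2)nn1Cc1cc(Cl)ccc1OCc1ccccc1` differs from compound 3 in one place: (pyridin-2-yl)methoxy in place of cyclohexylmethyl on a carbonyl carbon. For the measured compounds named here, no measured step makes exactly this exchange, but two steps touch the same carbonyl. The step of a 50-fold lower number from compound 2 to compound 3 (1.70 log units; beyond the scatter) shows how much is lost when the cyclohexyl is stripped away to leave a bare acetamido. Compound 1 carries a pyridinylmethyl on the other side of its amide, and compound 1 gives 79.4 nM, a number sitting between compound 2 and compound 3. Compound 4 keeps a ring-bearing group of similar size to the one it loses, yet the ring and its link to the carbonyl are different. In this assay a modest rise in the number is therefore expected, a 6.3-fold higher number from compound 3 to compound 4 (0.80 log units; beyond the scatter). The estimate for compound 4 is 40 nM, with a range from 10 nM to 160 nM.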

Compound 4, half-maximal inhibitory concentration: 79.4 nM
Estimate against measurement, compound 4: 2.0-fold (0.30 log units) below, and the stated range covers the measured number.
By their numbers in this assay, from the lowest: compound 3; then compounds 1 and 4 (each within the scatter of the next); then compound 2.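

At this carbonyl carbon, a ring-bearing group is not enough to keep the low number: a 13-fold higher number from compound 3 to compound 4 (1.10 log units; beyond the scatter) appears in this assay when (pyridin-2-yl)methoxy replaces cyclohexylmethyl. The new group still does better than a plain methyl, with a 4.0-fold lower number from compound 2 to compound 4 (0.60 log units; beyond the scatter) on that exchange, and no change at the digits printed from compound 1 to compound 4 (within the scatter) appears even though the two pyridine-bearing side chains are attached to the shared core differently. No measurement available here explains why (pyridin-2-yl)methoxy falls short of cyclohexylmethyl.

The change swaps the ring and adds an oxygen link in a single step, so the two contributions cannot be told apart. Cyclohexylmethoxy or (pyridin-2-yl)methyl on the same carbonyl would test each alone, and (pyridin-3-yl)methoxy would show whether the place of the ring nitrogen matters.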